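Swapping a benzyloxymethyl arm for a benzyl arm

A few compounds are considered here, and "the series" means these few. Any claim that something is new, unique, unknown or untested is made for them only; others in the source may bear on it.

Measured compounds:
- compound 1 `O=C1c2ccccc2N(COCc2ccccc2)S(=O)(=O)N1COCc1ccccc1`: 200000 nM
- compound 2 `O=C1c2ccccc2N(Cc2ccccc2Cl)S(=O)(=O)N1Cc1ccccc1Cl`: > 20000 nM
- compound 3 `O=C1c2ccccc2N(Cc2ccc(Cl)c(Cl)c2)S(=O)(=O)N1Cc1ccccc1`: 200000 nM

All three share a core that carries two arms on its ring nitrogens. In a functional assay on HEL cells (Homo sapiens) (a higher number here means that more compound is tolerated, a lower number that less compound is tolerated), compound 1 gives 200000 nM. Compound 3 gives 200000 nM in this assay, and within the usual scatter that is level with compound 1. Compound 2 is reported only as > 20000 nM, which is a limit of this assay rather than a measured number (the limit of > 20000 nM in this assay, at which 1 of the 3 values shown sits).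

The new compound, compound 4 `O=C1c2ccccc2N(Cc2ccccc2)S(=O)(=O)N1COCc1ccccc1`, differs from compound 1 in one place: phenyl in place of benzyloxy on a saturated chain carbon bound to a sulfonamide nitrogen in a ring. Within the data shown here, no step between two measured compounds covers this exact exchange, so the expectation rests on what is seen: compound 3, which also carries a plain benzyl arm, gives 200000 nM, level with compound 1.

For compound 4 the expected step of a 1.3-fold lower number from compound 1 to compound 4 (0.12 log units; within the scatter) is therefore none beyond the scatter. Compound 4 is estimated at 150000 nM in this assay, within a range from 40000 nM to 300000 nM.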

Compound 4, minimum cytotoxic concentration: 49000 nM
Estimate against measurement, compound 4: 3.1-fold (0.49 log units) above, and the stated range covers the measured number.
By their numbers in this assay, from the lowest: compound 4; then compounds 1 and 3 (each within the scatter of the next).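

In this assay, the exchange of (benzyloxy)methyl for benzyl on the sulfonamide nitrogen gives a 4.1-fold lower number from compound 1 to compound 4 (0.61 log units; beyond the scatter), so the cells tolerate less of compound 4 and this arm is not indifferent to the change. Among these compounds, the earlier compounds offered no pair differing in one place, so this is the first reading of a single exchange at this position: a benzyloxy group, with its one hydrogen-bond acceptor, leaves, and a phenyl group, with none, enters. What is shown gives no measured property that would account for the size of this step.

On these data alone, the second arm remains (benzyloxy)methyl in both compound 1 and compound 4, so it remains open whether the same exchange there would move the number in the same direction or by a similar amount. As far as these compounds go, it is also open how the number would respond to a longer chain between the sulfonamide nitrogen and the phenyl ring, or to an amine or a carboxylic acid carried on that arm.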